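Aryl substituent swap in the shared-core series

The compounds below may be only part of what the source reports. "The series", "measured", "known", "first", "only" and "open" are said of these compounds alone.

Compound 1 `O=c1ccc2cc(OCc3cc(-c4cccc5ccccc45)no3)ccc2o1` and compound 2 `CC(=O)Nc1ccc(-n2cc(COc3ccc4oc(=O)ccc4c3)nn2)cc1` carry the same core and were both read in a functional assay on HL-60 cells (Homo sapiens) for cytotoxicity, read by MTT assay, with a stated time of 48 h; a lower number here means a stronger inhibitor, a higher number a weaker inhibitor. In this assay compound 1 gives 41600 nM, and compound 2 gives 40400 nM, and the two numbers lie within the scatter of each other, so neither stands apart. Compound 3 `O=c1ccc2cc(OCc3cn(-c4ccc([N+](=O)[O-])cc4)nn3)ccc2o1` is the unmeasured member of the set. It differs from compound 2 by nitro in place of acetamido on an aromatic carbon. Among the compounds with values here, no measured pair in this set isolates such a swap, so the size of this step cannot be read from the data, and the two measured values sit at nearly the same level. For compound 3 the expected step of a 1.2-fold lower number from compound 2 to compound 3 (0.06 log units; within the scatter) is small, at most a drift toward a lower number, and not clearly beyond the scatter. Compound 3 is therefore estimated at 35000 nM, with a range from 12000 nM to 100000 nM.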

Compound 3, half-maximal inhibitory concentration: 46000 nM
Compound 3: middle estimate off by 1.3-fold (0.12 log units), on the low side; measured number inside the range.
By their numbers in this assay, from the lowest: compounds 2, 1 and 3 (each within the scatter of the next).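

In this assay, within the data shown here, nitro in place of acetamido on an aromatic carbon, para to a large group, gives a first single-change step for the series (a 1.1-fold higher number from compound 2 to compound 3 (0.06 log units; within the scatter)). Within this pair, the read-out does not separate acetamido from nitro at this position, even though the two groups differ in heavy atoms, hydrogen-bond donors and hydrogen-bond acceptors. No measurement at hand bears on the reason for this result.

Going by these compounds, whether any group at this position can move the read-out beyond the scatter remains open, and an amine, a carboxylic acid or a chlorine atom there would test it. Also open, on these data alone, is whether a longer chain between the shared core and the aromatic ring would leave this swap just as flat.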